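A few compounds are considered here, and "the series" means these few. Any claim that something is new, unique, unknown or untested is made for them only; others in the source may bear on it.

Among the measured compounds shown here, compound 1 `COc1ccc(N2C[C@@H](C)N[C@@H](C)C2)cc1NS(=O)(=O)c1ccc(-c2ccccn2)s1` is the stronger of the two compounds measured so far. For the measured compounds named here, in a functional assay for agonist activity at growth hormone secretagogue receptor type 1 (Homo sapiens), read by FLIPR (a higher number here means that more compound is needed for the effect, a lower number that less compound is needed), compound 1 gives 10 nM, the lowest of the two numbers known here. Going by the values given here, its only neighbour is compound 2 `CC(C)Oc1ccc(N2C[C@@H](C)N[C@@H](C)C2)cc1NS(=O)(=O)c1ccc(-c2ccccn2)s1`, which in this assay gives 100 nM; the step of a 10-fold higher number from compound 1 to compound 2 (1.00 log units; beyond the scatter) follows from the isopropyl in place of methyl on an oxygen on an aromatic ring. Compound 3 `COc1ccc(N2C[C@@H](C)N[C@@H](C)C2)cc1NS(=O)(=O)c1ccc(-c2cnco2)s1` differs from compound 1 elsewhere: 1,3-oxazol-5-yl in place of pyridin-2-yl on an aromatic carbon. Among the compounds with values here, no measured step touches the five-membered aromatic ring with 1 sulfur, so the change from compound 1 to compound 2 offers no guidance on size or direction, and the expectation rests on compound 1 alone. Compound 3 is therefore expected to stand near that value, with a wide range, a 2.5-fold higher number from compound 1 to compound 3 (0.40 log units; beyond the scatter). For compound 3 the estimate in this assay is 25 nM, between 5 nM and 150 nM.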

Compound 3, half-maximal effective concentration: 2.51 nM
For compound 3 the middle estimate is 10-fold (1.00 log units) above the measured one; measured number below the stated range.
By their numbers in this assay, from the lowest: compound 3; then compound 1; then compound 2.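

In this assay, the place on the aromatic carbon next to the ring sulfur proves open to change: 1,3-oxazol-5-yl in place of pyridin-2-yl gives a 4.0-fold lower number from compound 1 to compound 3 (0.60 log units; beyond the scatter). This is the first step shown at this place, and it runs in the opposite direction to the only earlier step, a 10-fold higher number from compound 1 to compound 2 (1.00 log units; beyond the scatter), which changed the group on the oxygen. The entering ring is five-membered rather than six-membered and carries two hydrogen-bond acceptors rather than one, but no measured finding links either difference to the result.

The compounds shown leave open whether a phenyl or a 1,3-thiazol-5-yl group at this place would give a similar number. They also leave open whether isopropyl on the oxygen would have the same effect with 1,3-oxazol-5-yl present.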